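Notes on compound 4, a 2-chlorophenyl swap from compound 2

A few compounds are considered here, and "the series" means these few. Any claim that something is new, unique, unknown or untested is made for them only; others in the source may bear on it.

compound 1 `Nc1ccccc1NC(=O)CCCNCC(=O)Nc1ccc(Cl)cc1` gives 45000 nM
compound 2 `Nc1ccccc1NC(=O)CCCNCC(=O)Nc1ccc(Br)cc1` gives 55500 nM
compound 3 `Nc1ccccc1NC(=O)c1ccc(NCC(=O)Nc2ccc([N+](=O)[O-])cc2)cc1` gives 6500 nM

In a functional assay on HCT-116 cells (Homo sapiens) for inhibition, read by MTT assay, with a stated time of 2 days (on this read-out higher numbers stand for weaker inhibition of growth and lower numbers for stronger inhibition of growth), compound 2 and compound 1 stand together at the top of the three numbers, with no order between them. Compound 3 (6500 nM) lies well lower, beyond the scatter, but it differs from compound 2 in more than one place and gives no direct guide here.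

Compound 4 `Nc1ccccc1NC(=O)CCCNCC(=O)Nc1ccccc1Cl` has not been measured. The change 2-chlorophenyl in place of 4-bromophenyl on an amide-type nitrogen puts 2-chlorophenyl in place of 4-bromophenyl on an amide-type nitrogen.

For the measured compounds named here, one measured step bears on this: a 1.2-fold higher number from compound 1 to compound 2 (0.09 log units; within the scatter) for bromo in place of chloro on an aromatic carbon. Going by the values given here, no measured compound carries 2-chlorophenyl, so that part of the change is untested. Among the compounds with values here, with only that small step as a guide, no shift beyond the scatter is expected in this assay, and no direction can be favoured. The estimated step is a 1.1-fold lower number from compound 2 to compound 4 (0.05 log units; within the scatter) (an expectation only). The expected value for compound 4 is 50000 nM (estimated range 25000 nM to 100000 nM).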

Compound 4, concentration for total growth inhibition: > 100000 nM
Compound 4: a limit, no number; the forecaster's own chance of this, stated with the estimate: 10%; at least 2.0-fold (0.30 log units) between middle value and limit.
By their numbers in this assay, from the lowest: compound 3; then compounds 1 and 2 (each within the scatter of the next). At a limit, above all of these: compound 4.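

Compound 4 stands at a limit of this assay and not at a number: the limit of > 100000 nM in this assay, at which 1 of the 4 values shown sits. Set against the 4-chlorophenyl group of compound 1, the 2-chlorophenyl group gives an at least 2.2-fold higher number from compound 1 to compound 4 (0.34 log units; beyond the scatter), so on this amide-type nitrogen the two chlorophenyl groups are not interchangeable, something the bromo for chloro step between compound 1 and compound 2 could not show. Set against the 4-bromophenyl group, the change gives an at least 1.8-fold higher number from compound 2 to compound 4 (0.25 log units; that floor lies within the scatter), a floor that lies within the scatter, so this pair alone fixes no separation and the firm reading rests on compound 1.

From the compounds shown here alone, how far compound 4 lies past its limit stays open. Also open, going by these compounds, is whether an unsubstituted phenyl group on the same nitrogen would read nearer compound 1 or compound 4, and how a 2-chlorophenyl group would read on the core of compound 3.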